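The source may hold more compounds than are shown below. What is called first, only, known or untested is meant among the compounds shown, and "the series" means these compounds.

Measured so far in a physicochemical assay for lipophilicity; on this read-out lower numbers stand for lower lipophilicity and higher numbers for higher lipophilicity
- Compound 1 `C/C=C/C=C/C(=O)OCC` gives 1.84
- Compound 2 `C/C=C/C=C/C(=O)OC(C)CC` gives 2.72
- Compound 3 `C/C=C/C=C/C(=O)OCCCCC` gives 3.1

Compound 3 stands highest of the three at 3.1 and the nearest to it is compound 2, while compound 1 lies furthest away. Compound 4 `C=CCOC(=O)/C=C/C=C/C` differs from compound 3 in one place vinyl in place of butyl on a saturated chain carbon bound to an oxygen next to a carbonyl group with vinyl in place of butyl on a saturated chain carbon bound to an oxygen next to a carbonyl group.

Among the measured compounds shown here, two measured steps bear on this change. The first is the large a number 1.26 log units higher from compound 1 to compound 3 (beyond the scatter) and the second is the modest a number 0.88 log units higher from compound 1 to compound 2 (beyond the scatter) in the same chain. In these three compounds more chain came with a higher number, and none goes against that. Vinyl is shorter than butyl, so a fall is expected, somewhat smaller than the first of those steps. For the measured compounds named here, no measured compound has a double bond in this chain, which leaves the estimate less certain. The expected step is a number 0.95 log units lower from compound 3 to compound 4 (beyond the scatter) and it should lie beyond the scatter. The estimated value for compound 4 is 2.15 with 1.8 to 2.5 as the expected range.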

Compound 4, partition coefficient: 2.24
Compound 4: middle estimate off by 0.09 log units, on the low side, within the range that was stated.
By their numbers in this assay, from the lowest: compound 1; then compound 4; then compound 2; then compound 3.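

In this assay, the first chain with a double bond still fits the earlier trend: vinyl in place of butyl on a saturated chain carbon bound to an oxygen next to a carbonyl group gives a number 0.86 log units lower from compound 3 to compound 4 (beyond the scatter) as the measured fall. The new chain also lands inside the series, with allyl in place of sec-butyl giving a number 0.48 log units lower from compound 2 to compound 4 (beyond the scatter) and vinyl in place of methyl giving a number 0.40 log units higher from compound 1 to compound 4 (beyond the scatter) as the two further steps. Across these four compounds, more chain still comes with a higher number, and none goes against that.

From the compounds shown here alone, how a propyl chain, the saturated counterpart of allyl, or a chain ending in an amine would compare at this place remains open. Nothing available explains why the numbers move as they do.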